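The compounds below may be only part of what the source reports. "The series", "measured", "known", "first", "only" and "open" are said of these compounds alone.

Measured compounds:

compound 1 `O=C([C@H]1CC2CCC1C2)N1CC(c2nc(-c3ccccc3)no2)C1` — 120 nM
compound 2 `O=C(C1CCCCC1)N1CC(c2nc(-c3cccc(F)c3)no2)C1` — 1000 nM
compound 3 `O=C(c1ccc(F)cc1)N1CC(c2nc(-c3cccc(F)c3)no2)C1` — 2400 nM

In an assay on HEK293 cells for positive allosteric modulation of metabotropic glutamate receptor 5 (Homo sapiens), read by FLIPR (a lower number here means that less compound is needed, a higher number that more compound is needed for the effect), compound 1 gives the lowest of the three numbers; compound 2 and compound 3 both give higher values, each beyond the scatter of compound 1. Within the data shown here, the one step measured between closely related compounds, a 2.4-fold higher number from compound 2 to compound 3 (0.38 log units; beyond the scatter), concerns the group on the carbonyl carbon and leaves the aromatic ring at the other end untouched.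

Among the measured compounds shown here, compound 4 `O=C([C@H]1CC2CCC1C2)N1CC(c2nc(-c3cccc(Cl)c3)no2)C1` keeps the carbonyl side of compound 1 and changes only that aromatic ring: chloro in place of hydrogen on an aromatic carbon. For the measured compounds named here, no measured pair differs only at this position, so the step of a 2.4-fold higher number from compound 2 to compound 3 (0.38 log units; beyond the scatter) does not bear on it directly, and the data give no basis for a shift beyond the scatter in either direction. Compound 4 is therefore expected to stay close to compound 1, with a step of a 1.2-fold lower number from compound 1 to compound 4 (0.08 log units; within the scatter). The estimate for compound 4 is 100 nM, within a range from 35 nM to 300 nM.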

Compound 4, half-maximal effective concentration: 74 nM
The estimate for compound 4 lay 1.4-fold (0.13 log units) above the measured number; low and high end bracket the measured number.
By their numbers in this assay, from the lowest: compounds 4 and 1 (each within the scatter of the next); then compound 2; then compound 3.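

In this assay, among these compounds, the change from phenyl to 3-chlorophenyl gives a 1.6-fold lower number from compound 1 to compound 4 (0.21 log units; within the scatter) and is the first measured step that concerns this aromatic ring alone. The earlier compounds shown here showed a step only on the carbonyl side, whereas this pair shows that chloro in place of hydrogen, meta to a large group, leaves the number within the scatter when the carbonyl side of compound 1 is kept. No measurement at hand explains this outcome.

The compounds shown leave open whether a larger or different group at this place, such as methoxy, nitrile or an amine, would also stay within the scatter. They also leave open whether chloro would give a similar step on other carbons of this ring or with the cyclohexyl carbonyl group of compound 2.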